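Azetidin-1-yl in place of dimethylamino on a carbonyl carbon

The source may hold more compounds than are shown below. What is called first, only, known or untested is meant among the compounds shown, and "the series" means these compounds.

Compound 1, `C=C(C)C(=O)NCCOc1ccc(Oc2c(-c3ccc(F)cc3)sc3cc(O)ccc23)cc1`, in a functional assay on Ishikawa cells (Homo sapiens) for antiproliferative activity, read by CCK-8 assay, with a stated time of 48 h (on this read-out higher numbers stand for weaker inhibition and lower numbers for stronger inhibition), reaches only a limit of the assay, > 25000 nM.
Compound 2, `O=C(/C=C/CNCCOc1ccc(Oc2c(-c3ccc(F)cc3)sc3cc(O)ccc23)cc1)N1CCCC1`, in this assay gives 11300 nM.
Compound 3, `CN(C)C(=O)/C=C/CNCCOc1ccc(Oc2c(-c3ccc(F)cc3)sc3cc(O)ccc23)cc1`, in this assay gives 11900 nM.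

Of the two numbers measured, compound 3 stands highest, with compound 2 nearest; the step between them, a 1.1-fold higher number from compound 2 to compound 3 (0.02 log units; within the scatter), is within the scatter. Compound 1 sits at the limit of this assay, (the limit of > 25000 nM in this assay, at which 1 of the 3 values shown sits). Measured against that limit, the steps of an at least 2.2-fold lower number from compound 1 to compound 2 (0.34 log units; beyond the scatter) and an at least 2.1-fold lower number from compound 1 to compound 3 (0.32 log units; beyond the scatter) are each at least modest, and both run in the same direction.

Compound 4, `O=C(/C=C/CNCCOc1ccc(Oc2c(-c3ccc(F)cc3)sc3cc(O)ccc23)cc1)N1CCC1`, differs from compound 3 in one place: azetidin-1-yl in place of dimethylamino on a carbonyl carbon. Within the data shown here, the one measured step that bears on this change is a 1.1-fold higher number from compound 2 to compound 3 (0.02 log units; within the scatter), where one amine group on the same carbonyl carbon was exchanged for another and the number stayed within the scatter. On that basis the step to compound 4 is expected to be of the same kind: no change beyond the scatter, a 1.0-fold lower number from compound 3 to compound 4 (0.01 log units; within the scatter). Compound 4 is therefore estimated to give 11500 nM in this assay, with a range from 5000 nM to 25000 nM.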

Compound 4, half-maximal inhibitory concentration: 6560 nM
Compound 4: middle estimate off by 1.8-fold (0.24 log units), on the high side; measured number inside the range.
By their numbers in this assay, from the lowest: compounds 4, 2 and 3 (each within the scatter of the next). At a limit, above all of these: compound 1.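

Azetidin-1-yl brings a four-membered ring to the carbonyl carbon, and in this assay neither a 1.8-fold lower number from compound 3 to compound 4 (0.26 log units; within the scatter) nor a 1.7-fold lower number from compound 2 to compound 4 (0.24 log units; within the scatter) leaves the scatter. These steps are larger than a 1.1-fold higher number from compound 2 to compound 3 (0.02 log units; within the scatter), but they still give no reliable separation among the three amine groups, so the dimethylamino, pyrrolidin-1-yl and azetidin-1-yl amides cannot be ranked at this position. The exchange of (1-methylethenyl)carbonyl on the amine nitrogen for 3-((azetidin-1-yl)carbonyl)prop-2-en-1-yl now gives an at least 3.8-fold lower number from compound 1 to compound 4 (0.58 log units; beyond the scatter), and compound 1 supplies only a limit for that comparison, not a number: the limit of > 25000 nM in this assay, at which 1 of the 4 values shown sits.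

The compounds shown leave open whether piperidin-1-yl or morpholin-4-yl on the same carbonyl carbon would stay within the scatter of these three amides, or whether a secondary amide such as the methylamide would move the number in this assay. They also leave open what a saturated propyl chain would do in place of the prop-2-en-1-yl chain, since all three amides compared here carry the double bond.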